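This account rests on a few compounds, and the source may have more. Where it says the series, first, only, none or still open, it means among the compounds named here.

Measured compounds:
- compound 1 `Nc1scc(-c2cc(C(F)(F)F)cc(C(F)(F)F)c2)c1C(=O)c1ccccc1`: 5.22
- compound 2 `Nc1scc(-c2ccccc2F)c1C(=O)c1ccc(Cl)cc1`: 5.1

In an assay on isolated protein with adenosine receptor A1 (Homo sapiens) as the target, read by ERK phosphorylation (on this read-out higher numbers stand for higher potency (the scale is a negative logarithm) and lower numbers for lower potency), compound 2 gives 5.1. Compound 1 gives 5.22 in this assay, and the two numbers lie within the usual scatter of each other, so neither compound stands apart. Compound 3 `Nc1scc(-c2cccc(F)c2)c1C(=O)c1ccc(Cl)cc1` is the same set of atoms joined differently: 3-fluorophenyl in place of 2-fluorophenyl on an aromatic carbon. Among the measured compounds shown here, no comparable pair among the measured compounds shows what such a move does, so the step of no change at the digits printed from compound 2 to compound 3 (within the scatter) is expected to be small, in no particular direction, and not beyond the scatter. Compound 3 is therefore estimated at 5.1, between 4.6 and 5.6.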

Compound 3, negative logarithm of the antagonist equilibrium constant: 5.88
For compound 3 the middle estimate is 0.78 log units below the measured one, and the stated range ends below it.
By their numbers in this assay, from the lowest: compounds 2 and 1 (each within the scatter of the next); then compound 3.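

In this assay, 3-fluorophenyl in place of 2-fluorophenyl gives a number 0.78 log units higher from compound 2 to compound 3 (beyond the scatter), although no atom is added or lost. This place on the shared core, an aromatic carbon two ring bonds from the ring sulfur, therefore responds to how the fluorine-bearing ring is arranged, not only to which atoms it holds. No supporting measurement here explains the step.

On these data alone, whether the gain depends on fluorine itself remains open. A comparison with 3-chlorophenyl or 3-methoxyphenyl at the same place would begin to answer that.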